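The source may report more compounds than this note shows. Statements on the series, on what has been measured and on what is new or still open speak of the compounds shown alone.

Measured so far in an assay on HeLa cells for binding affinity to 5-hydroxytryptamine receptor 6 (Homo sapiens); a lower number here means a stronger inhibitor, a higher number a weaker inhibitor:
compound 1 `COc1ccc(NS(=O)(=O)c2c(F)c(Br)cc(F)c2Br)cc1N1CCN(C)CC1` gives 3.16 nM
compound 2 `COc1ccc(NS(=O)(=O)c2ccc(Br)cc2)cc1N1CCN(C)CC1` gives 5.01 nM
compound 3 `COc1ccc(NS(=O)(=O)c2cc(Cl)cc(Cl)c2)cc1N1CCN(C)CC1` gives 2 nM

Compound 3 carries the lowest of the three numbers; compound 1 sits within the scatter of it, and only compound 2 lies beyond it. Among the measured compounds shown here, the single step between measured compounds that touches the group on the sulfonyl sulfur is a 2.5-fold lower number from compound 2 to compound 3 (0.40 log units; beyond the scatter), a modest change between two halogenated aryl rings.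

Compound 4 `COc1ccc(NS(=O)(=O)c2cn(C)cn2)cc1N1CCN(C)CC1` is not yet measured. Relative to compound 3 it carries 1-methyl-1H-imidazol-4-yl in place of 3,5-dichlorophenyl on a sulfonyl sulfur. For the measured compounds named here, no measured step covers a change of this kind: every measured compound carries a six-membered ring of carbon only on the sulfonyl sulfur, and none carries a five-membered ring with hetero atoms there. Going by the values given here, the one measured step shows only that exchanging one halogenated aryl ring for another shifts this assay modestly; the present change is different in kind, and a rise in the number is expected, most likely beyond the scatter. Compound 4 is therefore estimated at 30 nM, with a range of 8 nM to 150 nM. The step expected from this estimate is a 15-fold higher number from compound 3 to compound 4 (1.18 log units; beyond the scatter).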

Compound 4, inhibition constant: 794 nM
Estimate against measurement, compound 4: 26-fold (1.42 log units) below; the measured number lies above the stated range.
By their numbers in this assay, from the lowest: compounds 3, 1 and 2 (each within the scatter of the next, the first and the last beyond it); then compound 4.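

On the sulfonyl sulfur, the position that shifted only modestly between halogenated aryl rings proves highly sensitive to a change of ring type in this assay: 1-methyl-1H-imidazol-4-yl in place of 3,5-dichlorophenyl gives a 400-fold higher number from compound 3 to compound 4 (2.60 log units; beyond the scatter) and in place of 4-bromophenyl gives a 160-fold higher number from compound 2 to compound 4 (2.20 log units; beyond the scatter). Both large steps go from a six-membered aromatic ring of carbon only, carrying halogen, to a five-membered aromatic ring with 2 hetero atoms, so ring size, hetero atoms and loss of halogen change together and cannot be separated here. No supporting data bear on the size of these steps.

Which of these changes matters most remains open. An unsubstituted phenyl or a chlorothiophene on the sulfonyl sulfur would begin to separate them.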